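This account rests on a few compounds, and the source may have more. Where it says the series, first, only, none or still open, it means among the compounds named here.

Three compounds have been measured in a functional assay on SiHa cells (Homo sapiens) for inhibition, read by sulforhodamine B assay; a higher number here means a weaker inhibitor of growth, a lower number a stronger inhibitor of growth:

Compound 1, `Oc1cccc2[nH]c(-c3ccc(-c4ccc(-c5ccccc5)cc4)cc3)nc12`, gives 9710 nM.
Compound 2, `Oc1cccc2[nH]c(-c3ccc(-c4ccc(-c5ccc(F)cc5)cc4)cc3)nc12`, gives 9100 nM.
Compound 3, `Cc1ccc2[nH]c(-c3ccc(-c4ccc(-c5ccccc5)cc4)cc3)nc2c1`, gives 35200 nM.

Compound 2 differs from compound 1 in one place: fluoro in place of hydrogen on an aromatic carbon. That change made a step of a 1.1-fold lower number from compound 1 to compound 2 (0.03 log units; within the scatter), so the two numbers cannot be told apart. Compound 3 carries a different core; how its core differs from that of compound 1 is not broken down here. What the two values show is that compound 3 gives a higher number than compound 1, by more than the usual scatter, in this assay.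

Compound 4, `Cc1ccc2[nH]c(-c3ccc(-c4ccc(-c5ccc(F)cc5)cc4)cc3)nc2c1`, has not been measured yet. It differs from compound 3 in exactly the way compound 2 differs from compound 1: fluoro in place of hydrogen on an aromatic carbon. Within the data shown here, the same change is made on the same kind of position, so the earlier step is the only guide. Because the step of a 1.1-fold lower number from compound 1 to compound 2 (0.03 log units; within the scatter) was within the scatter, the step from compound 3 to compound 4 is expected to be small as well, about a 1.1-fold lower number from compound 3 to compound 4 (0.04 log units; within the scatter) in this assay. Compound 4 is therefore estimated at 32000 nM, most likely between 15000 nM and 70000 nM.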

Compound 4, concentration for 50% growth inhibition: 41000 nM
Compound 4: the middle estimate sits 1.3-fold (0.11 log units) below what was measured, within the range that was stated.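

On the second core, the change from phenyl to 4-fluorophenyl makes a step of a 1.2-fold higher number from compound 3 to compound 4 (0.07 log units; within the scatter) in this assay, so the two numbers cannot be told apart. Set beside the earlier step, the result is the same on both cores, a step too small to read: the same change on two cores in this assay, a 1.1-fold lower number (0.03 log units; within the scatter) from compound 1 to compound 2 and a 1.2-fold higher number (0.07 log units; within the scatter) from compound 3 to compound 4, 1.2-fold (0.09 log units) apart, within the scatter of two such steps This shows that, in this assay, the fluoro group leaves the number practically where it was on these two cores, but it does not show that the same would hold on a third core or in another assay, and with neither step beyond the scatter, there is no clear shift whose size or direction could be seen to carry over.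

The compounds shown leave open whether another group at that same position, such as chloro, methoxy, an amine or a carboxylic acid, would move the number beyond the scatter on either core. They also leave open whether such a larger step would be the same size on both cores.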